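Notes on the series: from compound 1 to compound 3

A few compounds are considered here, and "the series" means these few. Any claim that something is new, unique, unknown or untested is made for them only; others in the source may bear on it.

Measured so far in a functional assay on the whole organism (strain albino) for inhibition, with Rattus norvegicus as the target, read by paw edema, in the formalin test, with stated times of 1 h and 4 h, at a dose of 10 mg/kg by the oral route; a higher number here means more inhibition at the dose given (going by the name of the read-out), a lower number less inhibition:
compound 1 `Cc1c(C(N)=O)sc2nc(N/N=C/c3ccc(Br)cc3)n(Cc3ccccc3)c(=O)c12` gives 44%
compound 2 `Cc1c(C(N)=O)sc2nc(-n3nc(-c4ccc(Cl)cc4)cc3N)n(Cc3ccccc3)c(=O)c12` gives 46%

Compound 1 stands at the lower of the two numbers in this assay, but the nearest compound, compound 2, differs from it only by an amount within the usual scatter, so no order between the two can be drawn.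

Compound 3 `CC1=NN(c2nc3sc(C(N)=O)c(C)c3c(=O)n2Cc2ccccc2)C(=O)C1` is not yet measured in this assay. It differs from compound 1 in one place:

a group of 7 heavy atoms (4 carbon, 2 nitrogen, 1 oxygen; one five-membered non-aromatic ring with 2 hetero atoms) in place of a group of 10 heavy atoms (7 carbon, 2 nitrogen, 1 bromine; one six-membered aromatic ring of carbon only), on an aromatic carbon

The change sits on an aromatic carbon of a six-membered aromatic ring with 2 nitrogen, part of a fused or bridged system of two rings, between two ring nitrogen atoms, ortho to a benzyl group.

For the measured compounds named here, no step between two measured compounds that differ in one place exists in this set, so the size of a change at this place cannot be read from a precedent. The two measured compounds carry different groups at this place and still give numbers within the scatter of each other, which gives no sign of a large move in this assay. A step from compound 1 to compound 3 of none beyond the scatter, or a small loss, is expected; the estimated step of a number 4 percentage points lower from compound 1 to compound 3 (within the scatter) is meant to lie within that scatter. For compound 3 in this assay the expected value is 40%, with a range from 25% to 55%.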

Compound 3, a percentage reported as inhibition, in the whole organism at one dose (the size of the read-out at that dose, not a potency): 46%
Compound 3: the middle estimate sits 6 percentage points below what was measured; the measured number falls inside the stated range.
By their numbers in this assay, from the lowest: compounds 1, 2 and 3 (each within the scatter of the next).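

In this assay this position now has its first one-place step: a number 2 percentage points higher from compound 1 to compound 3 (within the scatter), and that step lies within the scatter. On the aromatic carbon between two ring nitrogen atoms, the group of 7 heavy atoms with its five-membered non-aromatic ring replaces the group of 10 heavy atoms with its six-membered aromatic ring of carbon only, so the loss of that aromatic ring, the bromine and the hydrogen-bond donor brings no readable change in this read-out at this dose. Nothing available here explains why the two groups read alike.

The compounds shown leave open whether a much smaller group at this carbon, such as a free amine or a methyl group, or a carboxylic acid, would also stay within the scatter of compound 1. On these data alone, the read-out is also the size of the effect at one dose and not a potency, so any difference between compound 1 and compound 3 at other doses remains open.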